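The source may report more compounds than this note shows. Statements on the series, on what has been measured and on what is new or still open speak of the compounds shown alone.

The measured compounds: compound 1 `O=C1COc2ccc(-c3cccc(NS(=O)(=O)c4ccc(F)cc4)c3)cc2N1c1ccccc1` gives in a functional assay on A-375 cells (Homo sapiens) for antiproliferative activity, read by MTT assay, with a stated time of 72 h (a higher number here means a weaker inhibitor, a lower number a stronger inhibitor), only the limit > 40000 nM. Compound 2 `Cc1ccc(N2C(=O)COc3ccc(-c4cnc5ccccc5c4)cc32)cc1` likewise gives only the limit > 40000 nM. Compound 3 `COc1ccc(N2C(=O)COc3ccc(-c4cnc(OC)c(NS(=O)(=O)c5ccc(F)cc5)c4)cc32)cc1` gives 18400 nM.

Compound 2 therefore stands at a limit rather than at a number; it shares the limit of > 40000 nM in this assay, at which 2 of the 3 values shown sit, with compound 1, and compound 3 alone returns a number. Compound 4 `O=C1COc2ccc(-c3cnc4ccccc4c3)cc2N1` has not been measured in this assay. It differs from compound 2 by hydrogen in place of 4-methylphenyl on an amide-type nitrogen in a ring. For the measured compounds named here, no step between measured compounds is available, so the size of this change cannot be read from the data. Compound 2 shows no measurable inhibition, and compound 4 is expected to behave the same way, with an expected step of a number no higher from compound 2 to compound 4 (the limit leaves the size open) amounting to nothing beyond the scatter. For compound 4 the estimate in this assay is 40000 nM, within 15000 nM to 100000 nM, most likely reported again as a limit.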

Compound 4, half-maximal inhibitory concentration: > 40000 nM
Compound 4: only a limit was reported (the forecaster's own chance of this, stated with the estimate: 75%); the middle value sits exactly at the limit.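

Compound 2 and compound 4 both stop at a limit rather than a number, so no step between them can be read in this assay: the limit of > 40000 nM in this assay, at which 3 of the 4 values shown sit.

The compounds shown leave open whether hydrogen in place of 4-methylphenyl on an amide-type nitrogen in a ring changes activity at all.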